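A Fluoro for Chloro Swap at One Carbon

This account rests on a few compounds, and the source may have more. Where it says the series, first, only, none or still open, it means among the compounds named here.

In a functional assay on RS4-11 cells (Homo sapiens) for inhibition, read by CCK-8 assay, with a stated time of 48 h, tested at 20 uM (a higher number here means more inhibition of growth at the concentration tested, a lower number less inhibition of growth), compound 1 `Cc1ccc(S(=O)(=O)Oc2ccccc2/C=C(\C#N)C(=O)Nc2nnc(Cc3cccc4ccccc34)s2)cc1` gives 73% of inhibition and compound 2 `N#C/C(=C\c1ccccc1OS(=O)(=O)c1ccc(Cl)cc1)C(=O)Nc1nnc(Cc2cccc3ccccc23)s1` gives 68% of inhibition, which places compound 2 level with compound 1 within the scatter. Compound 3 `N#C/C(=C\c1ccccc1OS(=O)(=O)c1ccc(F)cc1)C(=O)Nc1nnc(Cc2cccc3ccccc23)s1` differs from compound 2 by fluoro in place of chloro on an aromatic carbon with fluoro in place of chloro on an aromatic carbon. Within the data shown here, the one measured step bearing on this is a number 5 percentage points lower from compound 1 to compound 2 (within the scatter) for chloro in place of methyl on that carbon. No step beyond the scatter is therefore expected in this assay here. The estimated change is a number 1 percentage points higher from compound 2 to compound 3 (within the scatter) and it stays small. Compound 3 is expected at 69% with an estimated range of 56% to 82% for this measurement.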

Compound 3, percent growth inhibition at one concentration: 68%
Compound 3: the middle estimate sits 1 percentage points above what was measured, within the range that was stated.
By their numbers in this assay, from the lowest: compounds 2, 3 and 1 (each within the scatter of the next).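

In this assay, fluoro in place of chloro gives no change at the digits printed from compound 2 to compound 3 (within the scatter) and fluoro in place of methyl gives a number 5 percentage points lower from compound 1 to compound 3 (within the scatter) on this carbon para to a large group. Among these compounds, three small substituents have now been compared here, and no step among them leaves the scatter. Nothing available explains this tolerance.

On these data alone, what stays open is whether an amine or a carboxylic acid on this carbon would also stay level with these three compounds. A single test concentration also leaves any differences in potency at other concentrations unresolved.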